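Replacing the pyridin-3-yl group on the carbonyl carbon

This account rests on a few compounds, and the source may have more. Where it says the series, first, only, none or still open, it means among the compounds named here.

Of the compounds shown here, three of the shared core have been measured in a toxicity assay on WI-38 cells (Homo sapiens) for cytotoxicity, read by MTT assay, with a stated time of 48 h; on this read-out higher numbers stand for weaker inhibition and lower numbers for stronger inhibition. Compound 1 `O=C(/C=C/c1ccc2c(c1)B(O)OC2)c1cccs1` gives 26000 nM. Compound 2 `O=C(/C=C/c1ccc2c(c1)B(O)OC2)c1cccnc1` gives 76200 nM. Compound 3 `O=C(/C=C/c1ccc2c(c1)B(O)OC2)c1ccc(F)cc1` gives 7600 nM. Compound 2 therefore stands highest of the three numbers, with compound 1 nearest and compound 3 furthest. Among the compounds with values here, every measured step so far exchanges the group on the carbonyl carbon, and each moves the number beyond the scatter: a 2.9-fold higher number from compound 1 to compound 2 (0.47 log units; beyond the scatter), a 3.4-fold lower number from compound 1 to compound 3 (0.53 log units; beyond the scatter), and a 10-fold lower number from compound 2 to compound 3 (1.00 log units; beyond the scatter).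

Compound 4 `Nc1ccc(C(=O)/C=C/c2ccc3c(c2)B(O)OC3)cc1` has not yet been measured. Compared with compound 2 it carries 4-aminophenyl in place of pyridin-3-yl on a carbonyl carbon. The measured step that bears most directly on this change is a 10-fold lower number from compound 2 to compound 3 (1.00 log units; beyond the scatter), which likewise exchanges pyridin-3-yl for a six-membered aromatic ring of carbon only on the carbonyl carbon, though with 4-fluorophenyl rather than 4-aminophenyl. Within the data shown here, no measured step exchanges 4-fluorophenyl for 4-aminophenyl, so the size of the step is uncertain and is judged with a wide range. A lower number is expected for compound 4 in this assay, estimated as a 3.8-fold lower number from compound 2 to compound 4 (0.58 log units; beyond the scatter). Compound 4 is estimated at 20000 nM, with an expected range from 5000 nM to 70000 nM.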

Compound 4, half-maximal inhibitory concentration: 25400 nM
Beside the measured number, compound 4's estimate is 1.3-fold (0.10 log units) below it; low and high end bracket the measured number.
By their numbers in this assay, from the lowest: compound 3; then compounds 4 and 1 (each within the scatter of the next); then compound 2.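

In this assay, a second six-membered aromatic ring of carbon only on the carbonyl carbon also gives a lower number than pyridin-3-yl (  a 3.0-fold lower number from compound 2 to compound 4 (0.48 log units; beyond the scatter)), so compounds 3 and 4 both go the same way from compound 2. Within the data shown here, the group on that ring also counts, which the earlier compounds could not show, since none of their steps exchanged a group on an aromatic carbon: amino in place of fluoro gives a step beyond the scatter (a 3.3-fold higher number from compound 3 to compound 4 (0.52 log units; beyond the scatter)). 4-Aminophenyl and thiophen-2-yl on the carbonyl carbon cannot be told apart here (a 1.0-fold lower number from compound 1 to compound 4 (0.01 log units; within the scatter)), so a carbon-only ring does not by itself set the number apart from the sulfur-containing ring of compound 1.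

No measurement shown offers a reason for any of these steps. Still open, as far as these compounds go, is how far the number follows the group on the ring, for instance with a methoxy group, a dimethylamino group or a carboxylic acid in place of the amino group of compound 4, and where a plain phenyl ring on the carbonyl carbon would fall.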